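Replacing a difluorophenyl ring with trifluoromethyl

A few compounds are considered here, and "the series" means these few. Any claim that something is new, unique, unknown or untested is made for them only; others in the source may bear on it.

Compound 1 `O=C(Nc1ccc(F)c(-c2nc3ncc(-c4cc(F)ccc4F)cc3[nH]2)c1)N1CCCC1` gives 2800 nM
Compound 2 `O=C(Nc1ccc(F)c(-c2nc3ncc(-c4cccc(F)c4F)cc3[nH]2)c1)N1CCCC1` gives 1830 nM

In an ADME assay on the whole organism (Mus musculus, strain Swiss Webster) for pharmacokinetics, read by LC-MS, at a dose of 50 mg/kg by the oral route (a lower number here means less compound in the circulation, a higher number more compound in the circulation at the dose given), compound 2 gives 1830 nM and stands within the usual scatter of compound 1, which gives 2800 nM in the same test. Compound 3 `O=C(Nc1ccc(F)c(-c2nc3ncc(C(F)(F)F)cc3[nH]2)c1)N1CCCC1` starts from compound 2 and puts trifluoromethyl in place of 2,3-difluorophenyl on an aromatic carbon, so the whole six-membered aromatic ring of carbon only leaves.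

Among the measured compounds shown here, only one measured step bears on this, and only weakly: a 1.5-fold lower number from compound 1 to compound 2 (0.18 log units; within the scatter) in this test. That step exchanges one difluorophenyl for another. For the measured compounds named here, no measured compound lacks that ring, so the data give no direction for its loss, and no step beyond the scatter can be expected with confidence. The estimated move is a 1.2-fold higher number from compound 2 to compound 3 (0.08 log units; within the scatter) and is small beside the wide uncertainty. For compound 3 the expected value is 2200 nM with an estimated range from 600 nM to 8000 nM in this test.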

Compound 3, maximal plasma concentration: 1080 nM
Compound 3: the middle estimate sits 2.0-fold (0.31 log units) above what was measured, and the stated range covers the measured number.
By their numbers in this assay, from the lowest: compounds 3, 2 and 1 (each within the scatter of the next, the first and the last beyond it).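

Among the compounds shown here, this is the first measured compound in which the six-membered aromatic ring of carbon only is gone from this position, and in this assay trifluoromethyl in place of 2,3-difluorophenyl gives a 1.7-fold lower number from compound 2 to compound 3 (0.23 log units; within the scatter), so this exchange of a ring for a much smaller group cannot be told apart from the noise of repeated measurements. Set against the other ring, trifluoromethyl in place of 2,5-difluorophenyl gives a 2.6-fold lower number from compound 1 to compound 3 (0.41 log units; beyond the scatter), a modest step and the only one in this short set that clears the scatter, so the reading depends on which difluorophenyl compound serves as the reference, while oral dosing of compound 3 still gives a clear plasma level without that ring. No measurement on hand explains either step.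

For the compounds shown here, with only three compounds, it stays open whether the gap to compound 1 comes from losing the ring or is simply a property of that one fluorine pattern. Also open, from the compounds shown here alone, is how this position would respond to a group of another kind, such as a nitrile, a methyl, an amine or a carboxylic acid.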